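The source may hold more compounds than are shown below. What is called first, only, known or untested is meant among the compounds shown, and "the series" means these compounds.

Measured so far: compound 1 `O=C(OCCCCOc1ccccc1)c1cccc(=O)[nH]1` gives 94000 nM in an assay on isolated protein for inhibition of matrix metalloproteinase-9 (Homo sapiens); on this read-out lower numbers stand for stronger inhibition and higher numbers for weaker inhibition; compound 2 `O=C(OCc1ccccc1Cl)c1cccc(=O)[nH]1` gives 81000 nM; compound 3 `O=C(OCc1c(F)cccc1F)c1cccc(=O)[nH]1` gives 60000 nM.

The three numbers all fall within the usual scatter of one another, so no one of them can be set apart; compound 1 simply serves as the starting point for the next step. Compound 4 `O=C(OCCCCOc1ccccc1)c1cccc(S)n1` differs from compound 1 in one place: a group of 7 heavy atoms (5 carbon, 1 nitrogen, 1 sulfur; one six-membered aromatic ring with 1 hetero atom) in place of a group of 7 heavy atoms (5 carbon, 1 nitrogen, 1 oxygen; one six-membered aromatic ring with 1 hetero atom), on a carbonyl carbon. Going by the values given here, no measured pair shows this kind of exchange, so its effect in this assay cannot be read from the numbers above. The estimate for compound 4 is a lower number, expected to be beyond the scatter, with the step from compound 1 to compound 4 expected to be a 7.8-fold lower number from compound 1 to compound 4 (0.89 log units; beyond the scatter). Compound 4 is therefore expected to give about 12000 nM, within a range from 2000 nM to 60000 nM.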

Compound 4, half-maximal inhibitory concentration: 83000 nM
The estimate for compound 4 lay 6.9-fold (0.84 log units) below the measured number; the whole stated range lies below it.
By their numbers in this assay, from the lowest: compounds 3, 2, 4 and 1 (each within the scatter of the next).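

In this assay the exchange for 6-sulfanylpyridin-2-yl on the carbonyl carbon gives a 1.1-fold lower number from compound 1 to compound 4 (0.05 log units; within the scatter) and so does not separate the two compounds. Going by these compounds alone, this is the first pair differing in one place, and it shows that putting sulfur for oxygen here leaves the read-out within the scatter. No measurement shown offers an explanation of this result. Still open, going by these compounds, is whether another group at this place, such as a carboxylic acid or an amine in place of the sulfanyl group, would separate from compound 1. Also open, on these data alone, is whether the same exchange would read alike on compound 2 and compound 3.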